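The source may hold more compounds than are shown below. What is called first, only, known or untested is meant among the compounds shown, and "the series" means these compounds.

In a functional assay on Jurkat cells (Homo sapiens) for inhibition, read by CCK-8 assay, with a stated time of 48 h (a lower number here means a stronger inhibitor of growth, a higher number a weaker inhibitor of growth), compound 1 `Cc1ccccc1Nc1nc(NC2CCCCC2)ncc1Cl` gives > 100000 nM, which is a limit of the assay. Compound 2 `CCN1CCN(c2ccc(Nc3ncc(Cl)c(Nc4ccccc4C)n3)nc2)CC1` gives > 100000 nM, also a limit. Compound 3 `Cc1ccc(CNc2nc(Nc3ccc(N4CCN(C)CC4)cn3)ncc2Cl)cc1`, at 12700 nM, is the only one of the three with an actual number. Compound 4 `CCc1ccc(Nc2nc(Nc3ccc(N4CCN(C)CC4)cn3)ncc2Cl)cc1` has the same atoms as compound 3, joined differently: 4-ethylphenyl in place of 4-methylbenzyl on a nitrogen on an aromatic ring. Within the data shown here, no measured pair isolates this change. Compound 2 also has an aromatic ring on the corresponding nitrogen, and its > 100000 nM is again a limit, so a slight weakening is expected. The expected change, a 1.6-fold higher number from compound 3 to compound 4 (0.20 log units; within the scatter), is estimated to stay within the usual scatter. Compound 4 is estimated at 20000 nM, with an expected range of 4000 nM to 100000 nM.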

Compound 4, concentration for 50% growth inhibition: 11100 nM
Estimate against measurement, compound 4: 1.8-fold (0.26 log units) above, and the stated range covers the measured number.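

In this assay, putting 4-ethylphenyl in place of 4-methylbenzyl on this nitrogen gives a 1.1-fold lower number from compound 3 to compound 4 (0.06 log units; within the scatter). Among these compounds, this is the first change at this position that can be read, and the two groups, with the same atoms joined differently, are not told apart by this assay. Steps involving the other compounds cannot be read, as their values are limits: the limit of > 100000 nM in this assay, at which 2 of the 4 values shown sit. Still open, going by these compounds, is whether a longer chain in place of the ethyl, or an amine or a carboxylic acid on this aromatic ring, would move the number beyond the scatter.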